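This account rests on a few compounds, and the source may have more. Where it says the series, first, only, none or still open, it means among the compounds named here.

Going by the values given here, in an ADME assay on HEK293 cells for agonist activity at Toll-like receptor 8 (Homo sapiens), read by a luciferase reporter, with a stated time of 6 h (on this read-out lower numbers stand for an effect already at smaller amounts and higher numbers for an effect only at larger amounts of compound), compound 2 `CCCC(C)Nc1nc(N)nc2ccccc12` gives 0.17 uM, the lowest of the two numbers measured so far, while compound 1 `CC(C)CCNc1nc(N)nc2ccccc12` gives 2.11 uM. Among the compounds with values here, the single measured step, a 12-fold lower number from compound 1 to compound 2 (1.09 log units; beyond the scatter), shows that a change of the chain on this nitrogen can shift the read-out strongly. Compound 3 `COCCCNc1nc(N)nc2ccccc12` differs from compound 2 by 3-methoxypropyl in place of 1-methylbutyl on a nitrogen on an aromatic ring. That measured step bears on the new change, and a move of comparable size toward a higher number is expected because of a 12-fold lower number from compound 1 to compound 2 (1.09 log units; beyond the scatter). Compound 3 is therefore expected to give 2 uM, within a range from 0.5 uM to 8 uM. This amounts to an expected step of a 12-fold higher number from compound 2 to compound 3 (1.07 log units; beyond the scatter).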

Compound 3, minimum effective concentration: 0.01 uM
Beside the measured number, compound 3's estimate is 200-fold (2.30 log units) above it, and the stated range ends above it.
By their numbers in this assay, from the lowest: compound 3; then compound 2; then compound 1.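

In this assay, 3-methoxypropyl in place of 1-methylbutyl on the nitrogen gives a 17-fold lower number from compound 2 to compound 3 (1.23 log units; beyond the scatter), although both chains hold 5 heavy atoms; the entering chain has an oxygen and 1 hydrogen-bond acceptor. Methoxymethyl in place of isopropyl on a saturated chain carbon, two bonds along the chain from that nitrogen, gives a 210-fold lower number from compound 1 to compound 3 (2.32 log units; beyond the scatter). Nothing available explains either step. Still open, going by these compounds, is whether the oxygen itself matters: a plain butyl chain, or an amine in place of the methoxy group, would test this.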